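The source may report more compounds than this note shows. Statements on the series, on what has been measured and on what is new or still open speak of the compounds shown alone.

The measured compounds:
Compound 1, `COc1cc(N/C=C\C(=O)c2cn(-c3ccccc3)nc2-c2ccc(F)cc2)cc(OC)c1OC`, gives 7770 nM in a functional assay on HT-29 cells (Homo sapiens) for antiproliferative activity, read by MTT assay, with a stated time of 48 h; a lower number here means a stronger inhibitor, a higher number a weaker inhibitor.
Compound 2, `O=C(/C=C\Nc1ccc(C(F)(F)F)cc1)c1cn(-c2ccccc2)nc1-c1ccc(Cl)cc1`, reaches only a limit of the assay in this assay, reported as > 50000 nM.
Compound 3, `COc1ccc(-c2nn(-c3ccccc3)cc2C(=O)/C=C\Nc2ccc(C(F)(F)F)cc2)cc1`, gives 9870 nM in this assay.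

Of the two numbers, compound 1 has the lowest, but compound 3 sits within the scatter of it, so no order between them can be claimed. The value of compound 2 is only a limit, (the limit of > 50000 nM in this assay, at which 1 of the 3 values shown sits).

Compound 4, `COc1cc(N/C=C\C(=O)c2cn(-c3ccccc3)nc2-c2cc(OC)c(OC)c(OC)c2)cc(OC)c1OC`, is not yet measured. It differs from compound 1 in one place: 3,4,5-trimethoxyphenyl in place of 4-fluorophenyl on an aromatic carbon. Among the compounds with values here, one measured step bears on this change: an at least 5.0-fold lower number from compound 2 to compound 3 (0.70 log units; beyond the scatter), a swap toward a methoxy group on an aromatic carbon. The change to compound 4 brings three methoxy groups onto an aromatic ring at once, so a lower number of modest size is expected. Compound 4 is therefore estimated at 3000 nM, in a range from 800 nM to 12000 nM. This estimate means an expected step of a 2.6-fold lower number from compound 1 to compound 4 (0.41 log units; beyond the scatter).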

Compound 4, half-maximal inhibitory concentration: 8400 nM
Estimate against measurement, compound 4: 2.8-fold (0.45 log units) below; the measured number falls inside the stated range.
By their numbers in this assay, from the lowest: compounds 1, 4 and 3 (each within the scatter of the next). At a limit, above all of these: compound 2.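

In this assay, replacing 4-fluorophenyl with the larger 3,4,5-trimethoxyphenyl gives a 1.1-fold higher number from compound 1 to compound 4 (0.03 log units; within the scatter), so on this core, this position accepts the change with no measurable effect on the number. The earlier swap toward methoxy gave an at least 5.0-fold lower number from compound 2 to compound 3 (0.70 log units; beyond the scatter), but compounds 1 and 4 go against any general rule that methoxy groups at this position lower the number. Nothing measured here explains why the two changes differ.

On these data alone, it remains open how a single methoxy group, as 4-methoxyphenyl, would read on the core of compound 1. Also open, as far as these compounds go, is whether an amine or a carboxylic acid on that phenyl ring would shift the number beyond the scatter.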